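Chlorophenyl Position on a Urea and Thiourea Pair

The source may hold more compounds than are shown below. What is called first, only, known or untested is meant among the compounds shown, and "the series" means these compounds.

In a functional assay on U-373MG ATCC cells (Homo sapiens) for inhibition, read by MTT assay, with a stated time of 72 h (on this read-out lower numbers stand for stronger inhibition and higher numbers for weaker inhibition), the three measured compounds give the following numbers:

Compound 1, `CC1(C)CC(NC(=S)Nc2cccc(Cl)c2)c2cc(Br)ccc2O1`: 8000 nM
Compound 2, `CC1(C)CC(NC(=O)Nc2ccc(Cl)cc2)c2cc(Cl)ccc2O1`: 19000 nM
Compound 3, `CC1(C)CC(NC(=S)Nc2ccc(Cl)cc2)c2cc(Br)ccc2O1`: 7000 nM

Compound 2 gives the highest number of the three in this assay, and its gaps to compound 1 and to compound 3 both lie beyond the usual scatter. Compound 3 and compound 1 differ in one place, (3-chlorophenyl in place of 4-chlorophenyl on an amide-type nitrogen), and that change produced a 1.1-fold higher number from compound 3 to compound 1 (0.06 log units; within the scatter), so the two values cannot be ordered. How the core of compound 2 differs from the core of compound 3 is not broken down here.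

Compound 4, `CC1(C)CC(NC(=O)Nc2cccc(Cl)c2)c2cc(Cl)ccc2O1`, has not yet been measured in this assay. It differs from compound 2 by 3-chlorophenyl in place of 4-chlorophenyl on an amide-type nitrogen. Going by the values given here, this is the same kind of change as the one from compound 3 to compound 1, but not the same: in the earlier pair the amide-type nitrogen carrying the change has a thiocarbonyl carbon as its other neighbour, whereas in compound 2 and compound 4 that neighbour is a carbonyl carbon. The expectation for compound 4 is nonetheless a step of a 1.1-fold higher number from compound 2 to compound 4 (0.02 log units; within the scatter), resting on the observation that the same change gave a 1.1-fold higher number from compound 3 to compound 1 (0.06 log units; within the scatter). Among the compounds with values here, only one earlier example of the change is available, and it is on a different core, so the range is kept wide. Compound 4 is therefore estimated at 20000 nM in this assay, expected to fall between 9000 nM and 45000 nM.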

Compound 4, half-maximal inhibitory concentration: 21000 nM
For compound 4 the middle estimate is 1.1-fold (0.02 log units) below the measured one; low and high end bracket the measured number.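

In this assay, putting 3-chlorophenyl in place of 4-chlorophenyl on the amide-type nitrogen whose other neighbour is a carbonyl carbon gives a 1.1-fold higher number from compound 2 to compound 4 (0.04 log units; within the scatter). Set beside the same change where that neighbour is a thiocarbonyl carbon, the two steps agree: the same change on two cores in this assay, a 1.1-fold higher number (0.06 log units; within the scatter) from compound 3 to compound 1 and a 1.1-fold higher number (0.04 log units; within the scatter) from compound 2 to compound 4, 1.0-fold (0.01 log units) apart, within the scatter of two such steps In this series the change therefore carried from one core to the other without a readable effect on either, but this rests on only two pairs, and it shows neither that the same would hold on any further core nor that the place of the chlorine is unimportant on a phenyl group in general.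

The compounds shown leave open what sets compound 2 and compound 4 apart from the thiourea pair, since compound 1 and compound 3 differ from them both in the carbonyl or thiocarbonyl group and in the halogen on the core, and no compound here separates those two differences. They also leave open whether the same indifference would hold for another group in place of the chlorine, such as a methoxy group or a carboxylic acid, or for a phenyl group carrying no chlorine at all.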